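Series notes: chain lengthening at the aromatic nitrogen

A few compounds are considered here, and "the series" means these few. Any claim that something is new, unique, unknown or untested is made for them only; others in the source may bear on it.

Measured in a functional assay on HCT-116 cells (Homo sapiens) for inhibition; on this read-out lower numbers stand for stronger inhibition and higher numbers for weaker inhibition:

Compound 1, `CCNCc1cc(-c2c(C(=O)NCC)noc2-c2cc(C(C)C)c(O)cc2O)on1`, gives 45 nM.
Compound 2, `CCCNCc1cc(-c2c(C(=O)NCC)noc2-c2cc(C(C)C)c(O)cc2O)on1`, gives 117 nM.
Compound 3, `CCNC(=O)c1noc(-c2cc(C(C)C)c(O)cc2O)c1-c1ccn(CC)n1`, gives 25 nM.

The change from compound 1 to compound 2 is methyl in place of hydrogen on a saturated chain carbon, two bonds along the chain from an amine nitrogen, and it made a step of a 2.6-fold higher number from compound 1 to compound 2 (0.41 log units; beyond the scatter). Compound 3 carries a different core: the difference from compound 1 is 1-ethyl-1H-pyrazol-3-yl in place of 3-((ethylamino)methyl)-1,2-oxazol-5-yl on an aromatic carbon, and the step is a 1.8-fold lower number from compound 1 to compound 3 (0.26 log units; within the scatter), so the two cores cannot be told apart on this read-out. From compound 2 to compound 3 the step is a 4.7-fold lower number from compound 2 to compound 3 (0.67 log units; beyond the scatter).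

Compound 4, `CCCn1ccc(-c2c(C(=O)NCC)noc2-c2cc(C(C)C)c(O)cc2O)n1`, is not yet measured. Its change from compound 3 is methyl in place of hydrogen on a saturated chain carbon, two bonds along the chain from an aromatic nitrogen. Among the measured compounds shown here, this is the same kind of change as the one from compound 1 to compound 2, not the same: there the place is on a saturated chain carbon, two bonds along the chain from an amine nitrogen, here it is two bonds along the chain from an aromatic nitrogen. For the measured compounds named here, with only one earlier example, the expectation rests on compound 1 to compound 2, a 2.6-fold higher number from compound 1 to compound 2 (0.41 log units; beyond the scatter), and is a step of about a 2.0-fold higher number from compound 3 to compound 4 (0.30 log units; within the scatter), expected to be of similar or smaller size. Compound 4 is thus estimated at 50 nM, with a range from 20 nM to 125 nM.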

Compound 4, half-maximal inhibitory concentration: 49 nM
Estimate against measurement, compound 4: 1.0-fold (0.01 log units) above; low and high end bracket the measured number.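

In this assay, the change from ethyl to propyl gives a 2.0-fold higher number from compound 3 to compound 4 (0.29 log units; within the scatter), and set beside the earlier step it does not differ in size between the two cores: the same change on two cores in this assay, a 2.6-fold higher number (0.41 log units; beyond the scatter) from compound 1 to compound 2 and a 2.0-fold higher number (0.29 log units; within the scatter) from compound 3 to compound 4, 1.3-fold (0.12 log units) apart, within the scatter of two such steps. The change thus carries over from the core of compound 1 to the core of compound 3 as far as these two pairs can show, although the step on the core of compound 3 taken alone lies within the scatter, and the place differs, with the chain on an amine nitrogen in one pair and on an aromatic nitrogen in the other. Two pairs do not make a rule for other cores, and the exchanges of the whole group, a 2.4-fold lower number from compound 2 to compound 4 (0.38 log units; beyond the scatter) and a 1.1-fold higher number from compound 1 to compound 4 (0.04 log units; within the scatter), do not separate the effect of the chain from that of the group carrying it.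

The compounds shown leave open how a longer chain such as butyl, a branched chain such as isopropyl, or a chain ending in an amine would compare with propyl on either core. They also leave open whether the agreement between the two steps holds on any other read-out.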